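Propargyl to acetoxyethyl on a xanthine nitrogen

The source may hold more compounds than are shown below. What is called first, only, known or untested is meant among the compounds shown, and "the series" means these compounds.

Compound 1 `C=CCn1c(=O)[nH]c2[nH]cnc2c1=O` gives 461 nM in an assay on HEK293 cells for binding affinity to adenosine receptor A2b (Homo sapiens), read by radioligand binding; a lower number here means a stronger inhibitor, a higher number a weaker inhibitor.
Compound 2 `C#CCn1cnc2c1c(=O)n(C)c(=O)n2C` gives 9460 nM in this assay.

Of the two measured compounds, compound 2 stands with the higher number, and the gap to compound 1 lies beyond the usual scatter, so compound 2 is the weaker inhibitor in this assay among these two.

Compound 3 `CC(=O)OCCn1cnc2c1c(=O)n(C)c(=O)n2C` differs from compound 2 in one place: acetoxymethyl in place of ethynyl on a saturated chain carbon bound to an aromatic nitrogen. Going by the values given here, no measured pair shows this change, so the expectation rests on compound 2 alone. Starting from the weak value of compound 2 in this assay, the step from compound 2 to compound 3 is expected to be small, and its direction is uncertain: an estimated 1.3-fold higher number from compound 2 to compound 3 (0.10 log units; within the scatter), which may well fall within the scatter. For compound 3 the estimate in this assay is 12000 nM, with a range from 4000 nM to 40000 nM.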

Compound 3, inhibition constant: 23200 nM
Compound 3: the middle estimate sits 1.9-fold (0.29 log units) below what was measured; measured number inside the range.
By their numbers in this assay, from the lowest: compound 1; then compound 2; then compound 3.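

In this assay, going by these compounds alone, the change from propargyl to 2-acetoxyethyl gives a 2.5-fold higher number from compound 2 to compound 3 (0.39 log units; beyond the scatter), the first step that can be read at this position. The step is modest but lies beyond the scatter, so the end of this chain does affect the number, and the ethynyl group is the better of the two ends tested here. Acetoxymethyl, with its two hydrogen-bond acceptors, still leaves compound 3 with a measurable value, so the position accepts this larger group with only a modest change. Nothing in the data accounts for the direction or size of this step.

Going by these compounds, whether an amine, a carboxylic acid or a longer chain in this place would give a lower or a higher number remains open. Also open, on these data alone, is whether the same change would give a similar step on the core of compound 1, which differs from compound 2 in more than one place.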